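The compounds below may be only part of what the source reports. "The series", "measured", "known", "first", "only" and "open" are said of these compounds alone.

Compound 1, `O=C(O)c1cc2cc(-c3ccccc3)n(O)c2cc1C(=O)O`, gives 56200 nM in an assay on isolated protein for inhibition of Amine oxidase [flavin-containing] B (Homo sapiens), read by fluorescence and spectrophotometry, with a stated time of 20 min; a lower number here means a stronger inhibitor, a higher number a weaker inhibitor. Compound 2, `Cc1ccc(-c2cc3cc(C(=O)O)c(C(=O)O)cc3n2O)cc1`, gives only a limit in this assay, namely > 100000 nM.

Compound 2 thus sits at the limit of > 100000 nM in this assay, at which 1 of the 2 values shown sits, and no number is known for it. For the measured compounds named here, the single measured step, an at least 1.7-fold higher number from compound 1 to compound 2 (0.25 log units; that floor lies within the scatter), concerns methyl in place of hydrogen, and its floor lies within the scatter. Going by the values given here, compound 3, `COc1ccc(-c2cc3cc(C(=O)O)c(C(=O)O)cc3n2O)cc1`, differs from compound 2 by methoxy in place of methyl on an aromatic carbon, a change that no measured step covers. In this assay compound 3 is therefore expected to remain weak, with an estimated step that the limit leaves unreadable from compound 2 to compound 3. Compound 3 is estimated at 120000 nM, with a range from 40000 nM to 400000 nM.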

Compound 3, half-maximal inhibitory concentration: > 100000 nM
Compound 3: no number, only a limit (the forecaster's own chance of this, stated with the estimate: 60%); the middle value lies beyond the limit too.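

At the aromatic carbon para to a large group, a second substituent, methoxy, now joins methyl in failing to bring a readable number in this assay, so two different groups at this position end the same way: the limit of > 100000 nM in this assay, at which 2 of the 3 values shown sit. Methoxy in place of hydrogen gives an at least 1.7-fold higher number from compound 1 to compound 3 (0.25 log units; that floor lies within the scatter) and so shows no gain over the unsubstituted phenyl of compound 1. The step between the two limits cannot be read.

As far as these compounds go, whether an amine or a fluorine at this position would bring a value under the limit stays open. So does any order between methyl and methoxy.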